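A few compounds are considered here, and "the series" means these few. Any claim that something is new, unique, unknown or untested is made for them only; others in the source may bear on it.

Within the data shown here, in a functional assay on HT-29 cells (Homo sapiens) for cytotoxicity, read by MTT assay, with a stated time of 72 h (a lower number here means a stronger inhibitor, a higher number a weaker inhibitor), compound 1 `O=C(Nc1nc2ccc(Cl)cc2s1)c1cn(-c2ccccc2)nc1-c1ccccc1` gives 7810 nM, the only exact number so far. Compound 2 `Cc1ccc2nc(NC(=O)c3cn(-c4ccccc4)nc3-c3ccccc3)sc2c1` reaches only a limit of the assay, > 50000 nM. Compound 3 `COc1ccc(-c2nn(-c3ccccc3)cc2C(=O)Nc2nc3ccc(Cl)cc3s2)cc1` changes compound 1 from phenyl to 4-methoxyphenyl, with methoxy in place of hydrogen on an aromatic carbon. Among the measured compounds shown here, the only measured step, an at least 6.4-fold higher number from compound 1 to compound 2 (0.80 log units; beyond the scatter), put methyl in place of chloro at a different place, so it is just a loose guide to size and direction. A modest rise in the number is expected, and the estimated step is a 1.3-fold higher number from compound 1 to compound 3 (0.11 log units; within the scatter). The estimate for compound 3 is 10000 nM, with an expected range of 2500 nM to 40000 nM.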

Compound 3, half-maximal inhibitory concentration: 6570 nM
Compound 3: the middle estimate sits 1.5-fold (0.18 log units) above what was measured; low and high end bracket the measured number.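

Going from phenyl to 4-methoxyphenyl gives a 1.2-fold lower number from compound 1 to compound 3 (0.08 log units; within the scatter) in this assay. The earlier step, at a different place, moved the number beyond the scatter, whereas this first look at the phenyl shows that methoxy can sit here without a real change. Nothing measured here offers a reason for this flat result.

On these data alone, one group says little about the whole position, so it stays open whether an amine, a carboxylic acid or a longer chain in the same place would also leave the number unchanged or would shift it.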